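Halogen swap on the aryl ring of the shared core

The source may hold more compounds than are shown below. What is called first, only, known or untested is meant among the compounds shown, and "the series" means these compounds.

Measured so far:
compound 1 `CC(c1ccc(-c2ccccc2)c(F)c1)c1nnc2n1N=C(c1ccc(Cl)cc1)CS2`: 5000 nM
compound 2 `CC(c1ccc(-c2ccccc2)c(F)c1)c1nnc2n1N=C(c1ccc(Br)cc1)CS2`: 8500 nM

In a functional assay on FOCUS cells (Homo sapiens) for inhibition, read by sulforhodamine B assay, with a stated time of 72 h (a lower number here means a stronger inhibitor, a higher number a weaker inhibitor), compound 1 gives 5000 nM and compound 2 gives 8500 nM. Within the data shown here, the single step between them, a 1.7-fold higher number from compound 1 to compound 2 (0.23 log units; within the scatter), is within the scatter, so the two compounds are not separated by this assay and compound 2 stands alongside compound 1 rather than apart from it.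

Compound 3 `CC(c1ccc(-c2ccccc2)c(F)c1)c1nnc2n1N=C(c1ccc(F)cc1)CS2` has not yet been measured in this assay. Its difference from compound 2 is fluoro in place of bromo on an aromatic carbon. Among the measured compounds shown here, the only measured step that bears on a halogen exchange at this carbon is a 1.7-fold higher number from compound 1 to compound 2 (0.23 log units; within the scatter), and it stayed within the scatter. On that basis no step beyond the scatter is expected in this assay for compound 3 in either direction.

For compound 3 the estimated value is 7000 nM, with a range from 2500 nM to 20000 nM. For compound 3 this corresponds to an expected step of a 1.2-fold lower number from compound 2 to compound 3 (0.08 log units; within the scatter).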

Compound 3, half-maximal inhibitory concentration: 3500 nM
Compound 3: the middle estimate sits 2.0-fold (0.30 log units) above what was measured; low and high end bracket the measured number.
By their numbers in this assay, from the lowest: compounds 3, 1 and 2 (each within the scatter of the next, the first and the last beyond it).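

Fluoro in place of bromo at this aromatic carbon gives the first halogen exchange in this assay that clears the scatter: a 2.4-fold lower number from compound 2 to compound 3 (0.39 log units; beyond the scatter) is a modest step, so the halogen at this carbon can shift the number slightly. The exchange of chloro for fluoro does not separate its pair (a 1.4-fold lower number from compound 1 to compound 3 (0.15 log units; within the scatter)), so compound 1 stays unresolved from both neighbours and only the fluoro and bromo ends of the set are apart. Nothing measured here accounts for the step between the fluoro and bromo compounds.

As far as these compounds go, whether this carbon accepts anything other than a halogen remains open, for example a methoxy group, an amine or a carboxylic acid on the aryl ring. Also open, from the compounds shown here alone, is whether changes elsewhere on the shared core would produce larger steps than this halogen exchange does.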